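A few compounds are considered here, and "the series" means these few. Any claim that something is new, unique, unknown or untested is made for them only; others in the source may bear on it.

Values in a functional assay on NALM-6 cells (Homo sapiens) for cytotoxicity, with a stated time of 72 h (a higher number here means that more compound is needed for the effect, a lower number that less compound is needed), both of them limits of the assay:
- Compound 1 `C=C[C@@](C)(/C=C/c1ccc(Nc2ccccc2)cc1)CCC=C(C)C`: > 43400 nM
- Compound 2 `C=C[C@@](C)(/C=C/c1ccc(Nc2cc(F)c(F)cc2F)cc1)CCC=C(C)C`: > 43400 nM

Compound 2 has no measured number, only the limit > 43400 nM. Compound 3 `C=C[C@@](C)(/C=C/c1ccc(Nc2cc(F)c(F)c(F)c2)cc1)CCC=C(C)C` carries 3,4,5-trifluorophenyl in place of 2,4,5-trifluorophenyl on a nitrogen on an aromatic ring. The ring that enters has the same counts as the ring that leaves.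

Among the compounds with values here, only one measured step bears on this change: a step that the two limits leave unreadable from compound 1 to compound 2. Within the data shown here, its size cannot be read, and the series so far shows only (the limit of > 43400 nM in this assay, at which 2 of the 2 values shown sit). No step beyond the scatter is therefore expected in this assay, and no direction can be given. The expected step is a step that the limit leaves unreadable from compound 2 to compound 3. Another limit is the likeliest report for compound 3. As a number, compound 3 is estimated at 45000 nM, with an expected range of 15000 nM to 90000 nM.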

Compound 3, half-maximal effective concentration: > 43400 nM
Compound 3: a limit, no number; the forecaster's own chance of this, stated with the estimate: 75%; the middle value is on the limit's open side.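

In this assay compound 3 gives > 43400 nM, a limit and not a number. Within the data shown here, no step among compound 1, compound 2 and compound 3 can be read. The compounds shown leave open whether these three differ at all, and which change would give a measurable value: the limit of > 43400 nM in this assay, at which 3 of the 3 values shown sit.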